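The source may hold more compounds than are shown below. What is called first, only, known or untested is meant among the compounds shown, and "the series" means these compounds.

Compound 3 `Cc1cc(OCc2ccccc2)c(S(C)(=O)=O)cc1C(=O)N=C(N)N` gives 28 nM in a functional assay for inhibition of sodium/hydrogen exchanger (Oryctolagus cuniculus); on this read-out higher numbers stand for weaker inhibition and lower numbers for stronger inhibition. Among the three compounds measured it stands second highest: compound 1 `Cc1cc(-c2ccc(Cl)cc2)c(S(C)(=O)=O)cc1C(=O)N=C(N)N` gives 45 nM in this assay, and a 1.6-fold lower number from compound 1 to compound 3 (0.21 log units; within the scatter); compound 2 `Cc1cc(Sc2ccccc2Cl)c(S(C)(=O)=O)cc1C(=O)N=C(N)N` gives 14 nM in this assay, and a 2.0-fold higher number from compound 2 to compound 3 (0.30 log units; within the scatter). Within the data shown here, the only step beyond the scatter so far is a 3.2-fold lower number from compound 1 to compound 2 (0.51 log units; beyond the scatter), where a (2-chlorophenyl)sulfanyl group replaces 4-chlorophenyl on an aromatic carbon.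

Compound 4 `Cc1cc(OC2CCCC2)c(S(C)(=O)=O)cc1C(=O)N=C(N)N` differs from compound 3 in one place: cyclopentyl in place of benzyl on an oxygen on an aromatic ring. Among the measured compounds shown here, none of the measured steps swaps an aromatic ring for a saturated one at this position; they only show that three rather different groups on that aromatic carbon, in compounds 1, 2 and 3, all land within a narrow band of numbers. On that basis no step beyond the scatter is expected in this assay, and compound 4 is estimated at 40 nM, with a range of 15 nM to 110 nM, which would mean a 1.4-fold higher number from compound 3 to compound 4 (0.15 log units; within the scatter).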

Compound 4, half-maximal inhibitory concentration: 27 nM
Compound 4: middle estimate off by 1.5-fold (0.17 log units), on the high side, within the range that was stated.
By their numbers in this assay, from the lowest: compounds 2, 4, 3 and 1 (each within the scatter of the next, the first and the last beyond it).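

In this assay, among these compounds, cyclopentyl in place of benzyl on an oxygen on an aromatic ring gives a 1.0-fold lower number from compound 3 to compound 4 (0.02 log units; within the scatter), so compound 4 shows that the group on this oxygen need not be aromatic: the earlier compounds all carried an aromatic ring here, and a five-membered non-aromatic ring reads the same within the scatter. Cyclopentyloxy also stays within the scatter of both other groups, with a 1.9-fold higher number from compound 2 to compound 4 (0.29 log units; within the scatter) and a 1.7-fold lower number from compound 1 to compound 4 (0.22 log units; within the scatter), so compound 4 adds a fourth group to the same narrow band. Nothing measured here bears on the reason these different rings read alike.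

Every group on the oxygen so far is a ring of carbon only. On these data alone, whether an amine, a carboxylic acid or a longer chain would stay in this band remains open.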